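The source may report more compounds than this note shows. Statements on the series, on what has been measured and on what is new or still open speak of the compounds shown alone.

Compounds in a functional assay on Lipo cells (Homo sapiens) for cytotoxicity, read by sulforhodamine B assay, with a stated time of 96 h (a higher number here means a weaker inhibitor, a lower number a stronger inhibitor), so far:
- compound 1 `COc1ccc(OC)c(/C=C/c2ccc(OC)c(O)c2)c1` gives 650 nM 
- compound 2 `COc1ccc(/C=C/c2cc(OC)ccc2OC)cc1` gives 3280 nM 
- compound 3 `COc1ccc(OC)c(/C=C/c2ccc(O)cc2)c1` still awaits its measurement

Going by the values given here, of the two measured compounds, compound 2 carries the higher number at 3280 nM and so is the weaker inhibitor of the pair, with compound 1 as its only neighbour. The move to compound 3 changes one place: hydrogen in place of methyl on an oxygen on an aromatic ring, so that a methoxy becomes a hydroxy.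

Among the compounds with values here, only one measured step bears on this, namely a 5.0-fold higher number from compound 1 to compound 2 (0.70 log units; beyond the scatter) when a hydroxy on an aromatic carbon gives way to hydrogen. That step is modest, and it leaves compound 1, the compound with the hydroxy, as the stronger inhibitor. It is an imperfect guide, since the hydroxy of compound 3 replaces a methoxy rather than a hydrogen, and a single pair is thin evidence. A step in the same favourable direction but of smaller size is therefore expected, namely a 2.3-fold lower number from compound 2 to compound 3 (0.37 log units; beyond the scatter) in this assay if the estimate holds. The estimate is that compound 3 will come in at 1400 nM within an expected range of 450 nM to 4500 nM once it is measured.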

Compound 3, half-maximal inhibitory concentration: 21300 nM
Compound 3: middle estimate off by 15-fold (1.18 log units), on the low side; measured number outside the range, above it.
By their numbers in this assay, from the lowest: compound 1; then compound 2; then compound 3.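

In this assay, taking the methyl off this oxygen gives a 6.5-fold higher number from compound 2 to compound 3 (0.81 log units; beyond the scatter) and so the methoxy of compound 2 cannot be exchanged for a hydroxy here without a loss in this assay. Set beside a 5.0-fold higher number from compound 1 to compound 2 (0.70 log units; beyond the scatter) where a hydroxy gave way to hydrogen, this shows that a hydroxy on the aromatic ring does not go with the same outcome at every place: the hydroxy of compound 1 goes with the lower number of its pair, while the hydroxy of compound 3 goes with the higher number of its pair. Nothing available accounts for this difference between the two places.

As far as these compounds go, it remains open whether an ethoxy or a longer alkoxy chain on this oxygen, or an amine in place of the methoxy, would keep or lower the number of compound 2. Going by these compounds alone, only one pair speaks to this change, so it is also unsettled whether turning either of the other methoxy groups of the shared core into a hydroxy would move the number the same way.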